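Working notes on three measured compounds and one open

The source may report more compounds than this note shows. Statements on the series, on what has been measured and on what is new or still open speak of the compounds shown alone.

Measured so far:
- compound 1 `CC(C)OC(=O)N1CCC(Oc2ncnc3c2CCN3c2ccc(S(C)(=O)=O)cc2F)CC1` — 91%
- compound 2 `COCCOC(=O)N1CCC(Oc2ncnc3c2CCN3c2ccc(S(C)(=O)=O)cc2F)CC1` — 86%
- compound 3 `CC(C)c1noc(N2CCC(Oc3ncnc4c3CCN4c3ccc(S(C)(=O)=O)cc3F)CC2)n1` — 124%

All three share one core and were read in a functional assay on CHO-K1 cells with Glucose-dependent insulinotropic receptor (Homo sapiens) as the target, read by a luciferase reporter, with a stated time of 5 h; on this read-out lower numbers stand for smaller maximal responses and higher numbers for larger maximal responses. Compound 1 stands second highest of the three. Its nearest neighbour is compound 2: a number 5 percentage points lower from compound 1 to compound 2 (within the scatter), so the two cannot be told apart. The furthest is compound 3: a number 33 percentage points higher from compound 1 to compound 3 (beyond the scatter), and likewise a number 38 percentage points higher from compound 2 to compound 3 (beyond the scatter). Both large steps come from one kind of change, the replacement of a carbamate on the ring amine nitrogen by a 3-isopropyl-1,2,4-oxadiazol-5-yl group.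

Compound 4 `CC(C)OC(=O)N1CCC(Oc2nc(N)nc3c2CCN3c2ccc(S(C)(=O)=O)cc2F)CC1` keeps the isopropoxycarbonyl of compound 1 untouched and differs elsewhere: amino in place of hydrogen on an aromatic carbon. Among the compounds with values here, none of the measured steps touches this part of the core; every measured change sits on the ring amine nitrogen. Within the data shown here, there is therefore no measured step that bears directly on the change from compound 1 to compound 4, and no ground for expecting a step of the size seen with compound 3. The working expectation for compound 4 is a maximal response close to that of compound 1, with any difference estimated to stay within the scatter, that is a number 1 percentage points lower from compound 1 to compound 4 (within the scatter). The estimate for compound 4 in this assay is 90%, with a range from 70% to 110%.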

Compound 4, largest response reached (reported as percent of maximum), in percent of the reference or control that the assay uses: 33%
Compound 4: middle estimate off by 57 percentage points, on the high side; the whole stated range lies above it.
By their numbers in this assay, from the lowest: compound 4; then compounds 2 and 1 (each within the scatter of the next); then compound 3.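

In this assay the aromatic carbon between two ring nitrogen atoms turns out to be a sensitive place, with amino in place of hydrogen giving a number 58 percentage points lower from compound 1 to compound 4 (beyond the scatter) and the isopropoxycarbonyl group left untouched. Within the data shown here, the earlier steps all sit on the ring amine nitrogen, so this is the first sign that the shared core itself can move the maximal response, and a change of 1 heavy atom is enough to do so, in the opposite direction to a number 33 percentage points higher from compound 1 to compound 3 (beyond the scatter) on the same scale of large steps. No data at hand account for the loss of response at this position.

Open, going by these compounds, is whether a methyl group, a methoxy group or a chlorine atom on this aromatic carbon keeps a response like that of compound 1 or falls as the amino group does, and whether a methylamino group behaves like amino. Also open, on these data alone, is whether amino on this carbon lowers the response in the same way when the ring amine nitrogen carries the 3-isopropyl-1,2,4-oxadiazol-5-yl group of compound 3.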